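This account rests on a few compounds, and the source may have more. Where it says the series, first, only, none or still open, it means among the compounds named here.

Measured so far:
compound 1, `OC[C@H]1OC(n2c(Cl)nc3c(Cl)cc(Cl)cc32)[C@H](O)[C@@H]1O`: 230000 nM
compound 2, `OC[C@H]1OC(n2c(Br)nc3c(Cl)cc(Cl)cc32)[C@H](O)[C@@H]1O`: 150000 nM
compound 3, `OC[C@H]1OC(n2c(Cl)nc3c(Cl)c(Cl)ccc32)[C@H](O)[C@@H]1O`: a limit only, > 100000 nM

Compound 1 and compound 2 share one core; compound 3 has a core built from the same atoms joined differently. The difference between the two cores is not broken down here.

In a functional assay on KB cells (Homo sapiens) for inhibition (on this read-out lower numbers stand for stronger inhibition and higher numbers for weaker inhibition), compound 1 gives 230000 nM. Compound 2 gives 150000 nM in this assay. The change from compound 1 to compound 2 is bromo in place of chloro on an aromatic carbon, and the step it made was a 1.5-fold lower number from compound 1 to compound 2 (0.19 log units; within the scatter). For compound 3 this assay reports no number, only a limit, > 100000 nM. That limit is the one described as the limit of > 100000 nM in this assay, at which 1 of the 3 values shown sits.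

Compound 4, `OC[C@H]1OC(n2c(Br)nc3c(Cl)c(Cl)ccc32)[C@H](O)[C@@H]1O`, remains to be measured in this assay. It stands to compound 3 as compound 2 stands to compound 1: the change is bromo in place of chloro on an aromatic carbon, the same change as before, at a place described in the same words.

The expectation for compound 4 rests on the measured pair: because a 1.5-fold lower number from compound 1 to compound 2 (0.19 log units; within the scatter) lay within the scatter, the same change on the core of compound 3 is expected to move the number little, and the step estimated from compound 3 to compound 4 is a step that the limit leaves unreadable from compound 3 to compound 4. Compound 4 is therefore estimated at 150000 nM in this assay, with an expected range from 60000 nM to 400000 nM, and a reported limit rather than a number is judged more likely than not.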

Compound 4, half-maximal inhibitory concentration: > 100000 nM
Compound 4 was reported as a limit; the forecaster's own chance of this, stated with the estimate: 65%; the middle value is on the limit's open side.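

No step can be read from compound 3 to compound 4, since in this assay each is reported only as a limit: the limit of > 100000 nM in this assay, at which 2 of the 4 values shown sit.

The compounds shown leave open what actual numbers compound 3 and compound 4 would give, and whether bromo in place of chloro on an aromatic carbon changes the number at all on the core of compound 3.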